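Lengthening the linker once more: cytotoxicity on rat cells

The compounds below may be only part of what the source reports. "The series", "measured", "known", "first", "only" and "open" are said of these compounds alone.

Measured compounds:
compound 1, `CC(C)NC(=N)c1ccc2oc(-c3ccc(OCCCOc4ccccc4)cc3)cc2c1`: 45600 nM
compound 2, `CC(C)NC(=N)c1ccc2oc(-c3ccc(OCCCCCOc4ccccc4)cc3)cc2c1`: 20500 nM

Both compounds were tested in an ADME assay on L6 cells (Rattus norvegicus) for cytotoxicity, read by resazurin assay, with a stated time of 70 h; on this read-out lower numbers stand for stronger inhibition and higher numbers for weaker inhibition. Compound 1, `CC(C)NC(=N)c1ccc2oc(-c3ccc(OCCCOc4ccccc4)cc3)cc2c1`, gives 45600 nM, while compound 2, `CC(C)NC(=N)c1ccc2oc(-c3ccc(OCCCCCOc4ccccc4)cc3)cc2c1`, gives 20500 nM. Among the compounds with values here, compound 2 thus has the lowest of the two numbers, and the only measured step, a 2.2-fold lower number from compound 1 to compound 2 (0.35 log units; beyond the scatter), is a lengthening of the chain that joins the two aromatic oxygens.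

Compound 3, `CC(C)NC(=N)c1ccc2oc(-c3ccc(OCCCCCCOc4ccccc4)cc3)cc2c1`, continues in the same direction: phenoxymethyl in place of phenoxy on a saturated chain carbon, five bonds along the chain from an oxygen on an aromatic ring. Within the data shown here, the one step measured so far, a 2.2-fold lower number from compound 1 to compound 2 (0.35 log units; beyond the scatter), bears directly on this change, since it too lengthened this chain and gave a modest drop in the number. Whether a further step of this kind repeats that drop cannot be read from a single pair, so the expectation for this assay is a small downward move, near the edge of the scatter, by a 1.4-fold lower number from compound 2 to compound 3 (0.14 log units; within the scatter).

Compound 3 is therefore estimated at 15000 nM in this assay, with a range of 7000 nM to 35000 nM.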

Compound 3, half-maximal inhibitory concentration: 800 nM
Compound 3: middle estimate off by 19-fold (1.27 log units), on the high side; the measured number lies below the stated range.
By their numbers in this assay, from the lowest: compound 3; then compound 2; then compound 1.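

In this assay, the step of a 26-fold lower number from compound 2 to compound 3 (1.41 log units; beyond the scatter) is far larger than the earlier step of a 2.2-fold lower number from compound 1 to compound 2 (0.35 log units; beyond the scatter), so this part of the chain is much more sensitive than the first pair suggested: phenoxymethyl in place of phenoxy, on a saturated chain carbon five bonds along the chain from an oxygen on an aromatic ring, changes the number sharply even though it adds only a little to the molecule. Taken across all three compounds, the total change is a 57-fold lower number from compound 1 to compound 3 (1.76 log units; beyond the scatter) and most of it comes in the last step, so the number falls with each lengthening, with no compound here going against that order, but the fall is far from even. No measurement available here explains why this last step is so much larger than the one before it.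

The compounds shown leave open whether a longer chain than the one in compound 3 would lower the number further, hold it steady or raise it again. They also leave open whether the same sharp fall would appear with an anilino group, which has an amine in place of the oxygen of phenoxy, at the end of the chain.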